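From 4-methoxyphenyl to 3,5-dichlorophenyl on a shared core

The compounds below may be only part of what the source reports. "The series", "measured", "known", "first", "only" and "open" are said of these compounds alone.

Among the measured compounds shown here, only two compounds have numbers so far. In a functional assay on HCT-116 cells (Homo sapiens) for antiproliferative activity, read by sulforhodamine B assay, with a stated time of 48 h (on this read-out lower numbers stand for stronger inhibition and higher numbers for weaker inhibition), compound 1 `COc1cc(O)c(C(=O)/C=C/c2cccc(OC)c2OC)c(OC)c1` reads 3500 nM and compound 2 `COc1ccc(/C=C/C(=O)c2c(OC)cc(OC)cc2OCC=C(C)C)cc1` reads 7600 nM as the higher of the two numbers. Compound 2 is therefore the weaker inhibitor of the pair, and the gap between them lies beyond the usual scatter. The two differ in more than one place, so no measured single change is available as a guide.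

Compound 3 `COc1cc(OC)c(C(=O)/C=C/c2cc(Cl)cc(Cl)c2)c(OCC=C(C)C)c1` keeps the shared core of compound 2 and carries 3,5-dichlorophenyl in place of 4-methoxyphenyl on a double-bonded chain carbon bound to a double-bonded chain carbon (in full: 3,5-dichlorophenyl in place of 4-methoxyphenyl on a double-bonded chain carbon bound to a double-bonded chain carbon). For the measured compounds named here, the data hold no earlier example of this exchange, so no firm direction can be argued in this assay and the expectation is for no change beyond the scatter. The expected move is small, with a 1.5-fold lower number from compound 2 to compound 3 (0.18 log units; within the scatter) estimated to stay within that scatter. For compound 3 the estimated value is 5000 nM (expected range from 1800 nM to 14000 nM).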

Compound 3, half-maximal inhibitory concentration: 24500 nM
Compound 3: middle estimate off by 4.9-fold (0.69 log units), on the low side; measured number above the stated range.
By their numbers in this assay, from the lowest: compound 1; then compound 2; then compound 3.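

Among the compounds shown here, on a double-bonded chain carbon bound to a double-bonded chain carbon, the exchange of 4-methoxyphenyl for 3,5-dichlorophenyl gives the first comparison in this assay between compounds that differ in one place, and it comes out as a 3.2-fold higher number from compound 2 to compound 3 (0.51 log units; beyond the scatter), so this position does respond to what it carries and this exchange weakens inhibition. Both groups are six-membered aromatic rings of carbon only and neither carries a net charge, so the step goes with the substituents on that ring and not with the presence of the ring itself. Nothing available explains why the number rises with this exchange.

With only this one exchange at the position, the compounds shown do not separate the loss of the methoxy group from the arrival of the two chlorine atoms, and compound 1 differs from both other compounds in more than one place, so it cannot settle this. They also leave open how an unsubstituted phenyl, or a phenyl bearing an amine or a carboxylic acid, would read at this position on the shared core.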